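This account rests on a few compounds, and the source may have more. Where it says the series, first, only, none or still open, it means among the compounds named here.

Working notes on the series. Compound 2 `COc1ccccc1-n1nc(C2CC(C)(C)OC(C)(C)C2)cc1-c1ccc(Cl)cc1` carries a 2,2,6,6-tetramethyloxan-4-yl group on the shared core; in an assay on HEK293 cells for inhibition of Voltage-dependent N-type calcium channel subunit alpha-1B (Homo sapiens), read by patch clamp, using a membrane potential dye (a lower number here means a stronger inhibitor, a higher number a weaker inhibitor), compound 2 gives 16 nM. Among the three measured compounds this is the second highest number. Compound 1 `COc1ccccc1-n1nc([C@H]2C[C@@H](C)O[C@@H](C)C2)cc1-c1ccc(Cl)cc1`, with 2,6-dimethyloxan-4-yl in that place, gives 12 nM in this assay, the nearest value; the step is a 1.3-fold higher number from compound 1 to compound 2 (0.12 log units; within the scatter). Compound 3 `CCOc1ccc(-c2cc(C3CC(C)(C)OC(C)(C)C3)nn2-c2ccccc2OC)cc1` carries ethoxy in place of chloro; in this assay compound 3 gives 29 nM, the furthest value, and the step is a 1.8-fold higher number from compound 2 to compound 3 (0.26 log units; within the scatter).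

The next compound, compound 4 `COc1ccccc1-n1nc(C2CCOC(C)(C)C2)cc1-c1ccc(Cl)cc1`, differs from compound 2 in one place: 2,2-dimethyloxan-4-yl in place of 2,2,6,6-tetramethyloxan-4-yl on an aromatic carbon. The oxane ring keeps one pair of methyl groups and loses the other. For the measured compounds named here, the step that bears on this is the one between compound 1 and compound 2, a 1.3-fold higher number from compound 1 to compound 2 (0.12 log units; within the scatter), where the same ring with two methyl groups more showed no change beyond the scatter. Taking two methyl groups away is therefore expected to give a step in this assay of no size beyond the scatter; the estimated step is a 1.1-fold lower number from compound 2 to compound 4 (0.06 log units; within the scatter). For compound 4 the estimate in this assay is 14 nM, with a range from 6 nM to 35 nM.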

Compound 4, half-maximal inhibitory concentration: 55 nM
Compound 4: middle estimate off by 3.9-fold (0.59 log units), on the low side; the whole stated range lies below it.
By their numbers in this assay, from the lowest: compounds 1, 2, 3 and 4 (each within the scatter of the next, the first and the last beyond it).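

Until now this position had shown only a step within the scatter; in this assay the change to 2,2-dimethyloxan-4-yl gives a 3.4-fold higher number from compound 2 to compound 4 (0.54 log units; beyond the scatter) and so shows that the oxane group on this aromatic carbon does affect the number. The second step, a 4.6-fold higher number from compound 1 to compound 4 (0.66 log units; beyond the scatter), shows that the count of methyl groups alone does not set the number: 2,6-dimethyloxan-4-yl and 2,2-dimethyloxan-4-yl each carry two methyl groups, yet the step between them lies beyond the scatter, while the two groups named with methyl at both 2 and 6 stay within the scatter of each other. No measurement at hand bears on the reason for these steps.

Open, going by these compounds, is how the plain oxan-4-yl group, with no methyl groups, or a 6-methyl group paired with a single 2-methyl group in other arrangements of the ring would stand against these three oxane groups. Also open, on these data alone, is whether a ring amine such as 2,2,6,6-tetramethylpiperidin-4-yl would be tolerated in place of the oxane, and whether ethoxy in place of chloro would give a similar step on the 2,2-dimethyloxan-4-yl compound.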